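Trifluoromethyl to Chloro: Estimating Compound 3

This account rests on a few compounds, and the source may have more. Where it says the series, first, only, none or still open, it means among the compounds named here.

compound 1 `COc1cc2cc(Oc3ccc(NC(=O)Nc4cccc(C(F)(F)F)c4)cc3)c(C)nc2cc1OC` gives 1700 nM
compound 2 `COc1cc2cc(Oc3ccc(NC(=O)Nc4ccc(Cl)c(C(F)(F)F)c4)cc3)c(C)nc2cc1OC` gives 991 nM

Both numbers come from a functional assay on NCI-H23 cells (Homo sapiens) for inhibition, read by sulforhodamine B assay, with a stated time of 48 h; a higher number here means a weaker inhibitor of growth, a lower number a stronger inhibitor of growth. Among the compounds with values here, compound 2 has the lowest of the two numbers, and its nearest neighbour is compound 1; the only measured step, a 1.7-fold lower number from compound 1 to compound 2 (0.23 log units; within the scatter), stays within the scatter, so the two cannot be ranked. Compound 3 `COc1cc2cc(Oc3ccc(NC(=O)Nc4ccc(Cl)c(Cl)c4)cc3)c(C)nc2cc1OC` is made from compound 2 by one change: chloro in place of trifluoromethyl on an aromatic carbon. Within the data shown here, no measured step exchanges a trifluoromethyl for a chloro, so the single known step, chloro in place of hydrogen, bears on this change only by showing that a small edit on the same ring left the number within the scatter. The expectation for compound 3 in this assay is therefore a small step, if any, with a slight lean toward a higher number. Compound 3 is estimated at 1500 nM, within 500 nM to 4500 nM. The step this estimate implies is a 1.5-fold higher number from compound 2 to compound 3 (0.18 log units; within the scatter), an expectation rather than a measurement.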

Compound 3, concentration for 50% growth inhibition: 3360 nM
Compound 3: the middle estimate sits 2.2-fold (0.35 log units) below what was measured; the range from low to high includes it.
By their numbers in this assay, from the lowest: compounds 2, 1 and 3 (each within the scatter of the next, the first and the last beyond it).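

In this assay, within the data shown here, exchanging trifluoromethyl for chloro at this position, ortho to a chloro group, gives a 3.4-fold higher number from compound 2 to compound 3 (0.53 log units; beyond the scatter) and so lies beyond the scatter, unlike the one step known before, which showed nothing that could be ranked. This position therefore does respond to which group sits on it, at least between these two groups on this ring. The wider comparison, a 2.0-fold higher number from compound 1 to compound 3 (0.30 log units; within the scatter) as printed, lies within the scatter, so compound 1 and compound 3 cannot be ranked, and nothing available here accounts for the size of either step.

The compounds shown leave open how a nitrile, a methyl or an amine at this position would compare with trifluoromethyl and chloro. They also leave open whether the same exchange would give a step of similar size on a ring without the chloro group.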